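Dropping the Methoxy on the Core of Compound 2

The source may report more compounds than this note shows. Statements on the series, on what has been measured and on what is new or still open speak of the compounds shown alone.

Three compounds have been measured in a functional assay on MCF7 cells (Homo sapiens) for cytotoxicity; on this read-out lower numbers stand for stronger inhibition and higher numbers for weaker inhibition:

Compound 1 `O=C(N/N=C\c1cn(Cc2ccc(Cl)cc2)c2ccc(Br)cc12)c1c[nH]c2ccccc12` gives 3200 nM.
Compound 2 `COc1ccc(Cn2cc(/C=N\NC(=O)c3c[nH]c4ccccc34)c3cc(OC)ccc32)cc1` gives 15000 nM.
Compound 3 `O=C(N/N=C\c1cn(Cc2ccc(Cl)cc2)c2cc(F)ccc12)c1c[nH]c2ccccc12` gives 6000 nM.

Among these three numbers, compound 2 stands highest, meaning it is the weakest inhibitor of the set. Compound 3 comes nearest to it, and compound 1 lies furthest away; both gaps are beyond the usual scatter, so compound 2 is clearly set apart from the other two.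

The next compound, compound 4 `COc1ccc(Cn2cc(/C=N\NC(=O)c3c[nH]c4ccccc34)c3ccccc32)cc1`, differs from compound 2 in one place on the shared core: hydrogen in place of methoxy on an aromatic carbon.

Among the measured compounds shown here, no measured pair in this set shows the effect of such a change, so the expectation rests on compound 2 alone. The step of a 1.3-fold lower number from compound 2 to compound 4 (0.10 log units; within the scatter) is expected to stay within the scatter, with no clear direction. Compound 4 is therefore estimated at 12000 nM in this assay, with a likely range from 4000 nM to 40000 nM.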

Compound 4, half-maximal inhibitory concentration: 12400 nM
Compound 4: middle estimate off by 1.0-fold (0.01 log units), on the low side; low and high end bracket the measured number.
By their numbers in this assay, from the lowest: compounds 1 and 3 (each within the scatter of the next); then compounds 4 and 2 (each within the scatter of the next).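

In this assay, hydrogen in place of methoxy on this aromatic carbon of the shared core gives a 1.2-fold lower number from compound 2 to compound 4 (0.08 log units; within the scatter). Among the compounds shown here, this pair is the first direct look at the position, and it shows that the methoxy here is not needed for the level of activity seen in compound 2, nor does it clearly hold that activity back. Nothing available explains why the two compounds read alike.

An amine, a carboxylic acid or a longer chain at this position could behave quite differently, since only methoxy and hydrogen are shown there. Also open, on these data alone, is whether hydrogen and methoxy would again fall within the scatter of each other in compounds that carry chlorine instead of the second methoxy, as compounds 1 and 3 do.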